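A few compounds are considered here, and "the series" means these few. Any claim that something is new, unique, unknown or untested is made for them only; others in the source may bear on it.

Measured in a functional assay on MCF7-DOX cells (Homo sapiens) for antiproliferative activity; on this read-out higher numbers stand for weaker inhibition and lower numbers for stronger inhibition:
- compound 1 `COc1cc(/C=C\Cc2cc(O)c3ccoc3c2)cc(OC)c1OC`: 28 nM
- compound 2 `COc1cc(/C=C\Cc2cc(OP(=O)(O)O)c3ccsc3c2)cc(OC)c1OC`: 487 nM

Of these two compounds, compound 1 has the lower number and so the stronger inhibition. Compound 2, at 487 nM, stands higher by a gap well beyond the scatter. The next compound, compound 3 `COc1cc(/C=C\Cc2cc(OP(=O)(O)O)c3ccoc3c2)cc(OC)c1OC`, differs from compound 1 in one place: a group of 4 heavy atoms (3 oxygen, 1 phosphorus; no ring) in place of a hydrogen atom, on an oxygen on an aromatic ring, on an oxygen on an aromatic ring. For the measured compounds named here, no measured pair shows this change, so the data give no direct size for it. Going by the values given here, a moderate step towards weaker inhibition in this assay is expected, beyond the scatter, and the value of compound 2 at 487 nM serves as the only upper guide. The expected move is a 4.6-fold higher number from compound 1 to compound 3 (0.67 log units; beyond the scatter). Compound 3 is estimated at 130 nM, with an expected range of 30 nM to 600 nM.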

Compound 3, half-maximal inhibitory concentration: 357 nM
For compound 3 the middle estimate is 2.7-fold (0.44 log units) below the measured one, and the stated range covers the measured number.
By their numbers in this assay, from the lowest: compound 1; then compounds 3 and 2 (each within the scatter of the next).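

In this assay, putting the group of 4 heavy atoms (3 oxygen, 1 phosphorus; no ring) in place of a hydrogen atom on an oxygen on an aromatic ring gives a 13-fold higher number from compound 1 to compound 3 (1.11 log units; beyond the scatter), the first direct size for this change, and a large one. Within this pair, the hydrogen atom on that oxygen goes with the stronger inhibition, although a single pair sets no general rule for the position. Nothing in the data shown accounts for the size of this step.

On these data alone, it remains open how other groups on that oxygen would compare, such as a methyl ether, an acetyl ester or an amino acid ester. As far as these compounds go, it is also open whether the same change would bring a step of similar size on the core of compound 2.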